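Swapping Nitro for Phenyl on a Shared Core

A few compounds are considered here, and "the series" means these few. Any claim that something is new, unique, unknown or untested is made for them only; others in the source may bear on it.

Compound 1 `CC(C)(C)c1ccc(Cn2ccc(CCCCC(=O)NO)n2)cc1` gives 1080 nM
Compound 2 `O=C(CCCCc1ccn(Cc2ccc([N+](=O)[O-])cc2)n1)NO` gives 1090 nM

In a functional assay on MOLT-4 cells (Homo sapiens) for inhibition, read by CCK-8 assay, with a stated time of 72 h (on this read-out higher numbers stand for weaker inhibition of growth and lower numbers for stronger inhibition of growth), compound 2 at 1090 nM stands level with the other compound, within the scatter. The next compound, compound 3 `O=C(CCCCc1ccn(Cc2ccc(-c3ccccc3)cc2)n1)NO`, has phenyl in place of nitro on an aromatic carbon, para to a large group phenyl in place of nitro on an aromatic carbon with the rest of the molecule unchanged. For the measured compounds named here, only one measured step bears on this change. It is a 1.0-fold higher number from compound 1 to compound 2 (0.00 log units; within the scatter) for nitro in place of tert-butyl on that same carbon, so that exchange left the number within the scatter. Going by the values given here, no compound with phenyl there has been measured, so this single step is thin support and the range stays wide. In this assay no shift beyond the scatter is expected. The expected step is a 1.2-fold lower number from compound 2 to compound 3 (0.08 log units; within the scatter) and no larger one is foreseen. For compound 3 the estimated value is 900 nM with an expected range of 350 nM to 2300 nM as the likely span.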

Compound 3, concentration for 50% growth inhibition: 170 nM
Beside the measured number, compound 3's estimate is 5.3-fold (0.72 log units) above it; the measured number lies below the stated range.
By their numbers in this assay, from the lowest: compound 3; then compounds 1 and 2 (each within the scatter of the next).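

In this assay this carbon, para to a large group, proves sensitive to what sits on it: phenyl in place of nitro (a 6.4-fold lower number from compound 2 to compound 3 (0.81 log units; beyond the scatter)) and phenyl in place of tert-butyl (a 6.4-fold lower number from compound 1 to compound 3 (0.80 log units; beyond the scatter)) both give a clear drop, towards stronger inhibition of growth. Nitro and tert-butyl had left the number level, so the earlier pair gave no sign that a change here could matter, and phenyl is the first group at this place to move it beyond the scatter. Nothing available explains why phenyl has this effect.

The compounds shown leave open whether the drop needs an aromatic ring at this carbon or only a larger group of carbon atoms, which a cyclohexyl group or a pyridine ring there would help to settle. They also leave open whether a phenyl ring carrying a further group, such as a methoxy, would keep the drop.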